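Adding a 4-aminobutyl side chain to compound 3

A few compounds are considered here, and "the series" means these few. Any claim that something is new, unique, unknown or untested is made for them only; others in the source may bear on it.

Measured so far:
- compound 1, `CC[C@H](C)[C@H](NC(=O)CN(c1nc(Cl)nc2[nH]cnc12)C1CC1)C(=O)O`: 36%
- compound 2, `NC(=O)C[C@H](NC(=O)CN(c1nc(Cl)nc2[nH]cnc12)C1CC1)C(=O)O`: 43.1%
- compound 3, `O=C(O)CNC(=O)CN(c1nc(Cl)nc2[nH]cnc12)C1CC1`: 38.9%

All three share one core and differ only in the group on a saturated chain carbon bound to an amide-type nitrogen and a carbonyl carbon. In a functional assay on the whole organism (Tail, strain ICR) with Mus musculus as the target, in the tail flick test, with a stated time of 60 min, at a dose of 25 umol/kg by the oral route (on this read-out higher numbers stand for a stronger effect at the one dose given and lower numbers for a weaker effect), compound 3 stands second highest of the three numbers, yet its neighbours lie close: the step of a number 2.9 percentage points higher from compound 1 to compound 3 (within the scatter) and the step of a number 4.2 percentage points lower from compound 2 to compound 3 (within the scatter) both fall within the scatter, so no ordering among compounds 1, 2 and 3 can be claimed.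

Compound 4, `NCCCC[C@H](NC(=O)CN(c1nc(Cl)nc2[nH]cnc12)C1CC1)C(=O)O`, has not yet been tested. It differs from compound 3 as follows: 4-aminobutyl in place of hydrogen on a saturated chain carbon bound to an amide-type nitrogen and a carbonyl carbon.

The two measured steps that bear on this change both add or remove a side chain at the same place. Going from compound 1 to compound 3 replaced sec-butyl by hydrogen (a number 2.9 percentage points higher from compound 1 to compound 3 (within the scatter)), and going from compound 2 to compound 3 replaced carbamoylmethyl by hydrogen (a number 4.2 percentage points lower from compound 2 to compound 3 (within the scatter)); neither moved the number beyond the scatter. Accordingly the step of a number 1.1 percentage points higher from compound 3 to compound 4 (within the scatter) is expected to stay within the scatter, with no clear direction. Compound 4 is therefore estimated at 40%, within a range from 26% to 54%.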

Compound 4, a percentage reported as activity, at one dose (the size of the read-out at that dose, not a potency): 53.8%
Estimate against measurement, compound 4: 13.8 percentage points below; the measured number falls inside the stated range.
By their numbers in this assay, from the lowest: compounds 1, 3 and 2 (each within the scatter of the next); then compound 4.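

In this assay, the saturated chain carbon bound to an amide-type nitrogen and a carbonyl carbon now shows that its substituent can change the read-out, with a number a number 14.9 percentage points higher from compound 3 to compound 4 (beyond the scatter). Among the compounds shown here, the earlier swaps among hydrogen, sec-butyl and carbamoylmethyl stayed within the scatter, so this is the first step at this position to exceed it. The gain over those two side chains also exceeds the scatter, with a number 17.8 percentage points higher from compound 1 to compound 4 (beyond the scatter) and a number 10.7 percentage points higher from compound 2 to compound 4 (beyond the scatter), which makes compound 4 the strongest of the four at this single dose, though no measurement shown explains why.

Still open, on these data alone, is whether this step belongs to the terminal amine or to the length of the chain: an unbranched butyl chain with no amine, or a 4-hydroxybutyl chain, would separate the two, and 2-aminoethyl or 6-aminohexyl would test the length. A guanidine at the chain end would show whether the amine itself can be replaced, and doses beyond the single one shown would be needed to tell whether the stronger effect of compound 4 at this dose also holds at other doses.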